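Acetylphenyl in Place of Carbamoylphenyl on the Ring Amine

The source may report more compounds than this note shows. Statements on the series, on what has been measured and on what is new or still open speak of the compounds shown alone.

Compound 1 `Cc1nc(-c2ccccc2)c(C(=O)N2CCN(c3cccc(C(N)=O)c3)CC2)o1` is one of two compounds tested in a functional assay on HL-60 cells (Homo sapiens) for inhibition, read by MTT assay, with a stated time of 72 h (on this read-out higher numbers stand for weaker inhibition and lower numbers for stronger inhibition), and in this assay compound 1 gives 71 nM, the only numerical result in the set. The other compound, compound 2 `COc1cccc(N2CCN(C(=O)c3oc(C)nc3-c3cccc(F)c3)CC2)c1`, is reported in this assay as "not active" (no number reported), so no number exists for it; compound 2 also differs from compound 1 at more than one place, and nothing can be drawn from the pair beyond these two results. Compound 3 `CC(=O)c1ccc(N2CCN(C(=O)c3oc(C)nc3-c3ccccc3)CC2)cc1` has not yet been measured. The change from compound 1 to compound 3 is 4-acetylphenyl in place of 3-carbamoylphenyl on an amine nitrogen in a ring. Within the data shown here, no step between two measured compounds that differ in one place is available, so the expectation rests on compound 1 alone and on the counted change, in which a hydrogen-bond donor leaves while the acceptor count stays the same. A modest move toward weaker inhibition, near the edge of the scatter, is expected, so compound 3 is expected to give 200 nM in this assay, within a range from 50 nM to 1500 nM. The step is thus estimated as a 2.8-fold higher number from compound 1 to compound 3 (0.45 log units; beyond the scatter).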

Compound 3, half-maximal inhibitory concentration: "not active" (no number reported)
Compound 3 has no reported number here; no gap can be computed for the estimate.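

Among these compounds, compound 3 is reported as "not active" in this assay without a number, while compound 1 gives 71 nM, so no step from compound 1 to compound 3 can be read. Nothing shown here offers an explanation for this result. The compounds shown leave open how much inhibition changes when 4-acetylphenyl takes the place of 3-carbamoylphenyl.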